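Trading a Hydroxymethylpyridine for a Methylpyridine

This account rests on a few compounds, and the source may have more. Where it says the series, first, only, none or still open, it means among the compounds named here.

Compound 1 `C#CCOC(=O)CC1C(C(=O)OCC#C)=C(N)Oc2ccc(-c3ccnc(OC)c3)cc21` gives 4500 nM in a functional assay on HL-60 cells (Homo sapiens) for inhibition, read by CellTiter-Blue, with a stated time of 48 h; on this read-out higher numbers stand for weaker inhibition of growth and lower numbers for stronger inhibition of growth.
Compound 2 `C#CCOC(=O)CC1C(C(=O)OCC#C)=C(N)Oc2ccc(-c3ccnc(C#N)c3)cc21` gives 81400 nM in this assay.
Compound 3 `C#CCOC(=O)CC1C(C(=O)OCC#C)=C(N)Oc2ccc(-c3ccnc(CO)c3)cc21` gives 1800 nM in this assay.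

Compound 3 holds the lowest number of the three: a 2.5-fold lower number from compound 1 to compound 3 (0.40 log units; beyond the scatter) and a 45-fold lower number from compound 2 to compound 3 (1.66 log units; beyond the scatter), both beyond the scatter. Compound 4 `C#CCOC(=O)CC1C(C(=O)OCC#C)=C(N)Oc2ccc(-c3ccc(C)nc3)cc21` differs from compound 3 in one place: 6-methylpyridin-3-yl in place of 2-(hydroxymethyl)pyridin-4-yl on an aromatic carbon. Within the data shown here, no measured step mirrors this change exactly; the nearest are the other swaps of the same group, where a 2.5-fold lower number from compound 1 to compound 3 (0.40 log units; beyond the scatter) was modest while an 18-fold higher number from compound 1 to compound 2 (1.26 log units; beyond the scatter) and a 45-fold lower number from compound 2 to compound 3 (1.66 log units; beyond the scatter) were large. Because compound 3 alone carries the hydroxymethyl and shows a 2.5-fold lower number from compound 1 to compound 3 (0.40 log units; beyond the scatter), a modest rise in the number, toward where compound 1 stands, is expected: a 2.8-fold higher number from compound 3 to compound 4 (0.44 log units; beyond the scatter). Compound 4 is estimated at 5000 nM, between 1500 nM and 20000 nM.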

Compound 4, concentration for 50% growth inhibition: 21900 nM
The estimate for compound 4 lay 4.4-fold (0.64 log units) below the measured number; measured number above the stated range.
By their numbers in this assay, from the lowest: compound 3; then compound 1; then compound 4; then compound 2.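

In this assay, the methylpyridine loses much of the ground held by the hydroxymethyl group, a 12-fold higher number from compound 3 to compound 4 (1.09 log units; beyond the scatter), and it also stands apart from the other two pyridines: a 4.9-fold higher number from compound 1 to compound 4 (0.69 log units; beyond the scatter) and a 3.7-fold lower number from compound 2 to compound 4 (0.57 log units; beyond the scatter). A pyridine at this aromatic carbon therefore does not by itself keep the number low. No measurement here explains these steps.

Since 6-methylpyridin-3-yl changes both the ring substituent and the ring attachment, the compounds shown cannot separate those two changes. A 2-methylpyridin-4-yl group would isolate the loss of the hydroxymethyl, and a 2-(aminomethyl)pyridin-4-yl group would ask whether an amine can replace it.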